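This account rests on a few compounds, and the source may have more. Where it says the series, first, only, none or still open, it means among the compounds named here.

Working notes on the series in an assay on BaF3 cells with thrombopoietin receptor (Homo sapiens) as the target, read by a luciferase reporter; on this read-out higher numbers stand for larger maximal responses and lower numbers for smaller maximal responses. Compound 1 `O=S(=O)(O)c1cc(O)c(/N=N/c2ccc(O)c3ccc(O)cc23)c2ccccc12` gives in this assay only the limit < 5%, which is a limit of the assay and not a number. Compound 2 `O=S(=O)(O)c1cc(O)c(NCc2c(O)ccc3ccccc23)c2ccccc12` likewise reports in this assay only the limit < 5%. Compound 3 `Cc1[nH]n(-c2cccc(C(F)(F)F)c2)c(=O)c1/N=N/c1c(O)cc(S(=O)(=O)O)c2ccccc12` is the single member with a numerical value, reaching 62% in this assay; the other two members sit at the limit of < 5% in this assay, at which 2 of the 3 values shown sit, so compound 3 stands alone on the numbers shown, and no ordering among the three beyond that can be stated.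

Compound 4 `Cc1[nH]n(-c2ccc(O)cc2)c(=O)c1/N=N/c1c(O)cc(S(=O)(=O)O)c2ccccc12` is not yet measured. It differs from compound 3 in one place: 4-hydroxyphenyl in place of 3-(trifluoromethyl)phenyl on an aromatic nitrogen. Among the measured compounds shown here, no step between measured compounds with a single change is available to calibrate this replacement, and compounds 1 and 2 differ from compound 3 in many places at once. The expectation therefore rests on compound 3 with 62% alone.

For compound 4 a step of a number 22 percentage points lower from compound 3 to compound 4 (beyond the scatter) in this assay is expected, a drop somewhat beyond the scatter, with a real chance that only a limit is reported. Compound 4 is estimated at 40% in this assay, within the range 10% to 70%.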

Compound 4, largest response reached (reported as efficacy), in percent of the reference or control that the assay uses: < 5%
Compound 4: only a limit was reported; the forecaster's own chance of this, stated with the estimate: 25%; at least 35 percentage points between middle value and limit.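

In this assay the series now has its first single-place step, and it falls on the aromatic nitrogen: 4-hydroxyphenyl in place of 3-(trifluoromethyl)phenyl gives a number at least 57 percentage points lower from compound 3 to compound 4 (beyond the scatter). For compound 4 the value < 5% is a limit of the assay and not a number. Among the compounds shown here, the shared core of compound 3 and compound 4 therefore does not keep a measurable maximal response with every aryl group on this nitrogen, and only one numerical value remains: the limit of < 5% in this assay, at which 3 of the 4 values shown sit.

The compounds shown do not separate the loss of the trifluoromethyl group from the arrival of the hydroxyl group, or either of these from the different ring place of each. As far as these compounds go, how an unsubstituted phenyl, or a phenyl carrying an amine or a carboxylic acid, would read out on this nitrogen remains open.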